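The compounds below may be only part of what the source reports. "The series", "measured", "known", "first", "only" and "open" are said of these compounds alone.

In an ADME assay on SW480 cells (Homo sapiens) for cytotoxicity, read by MTT assay, with a stated time of 72 h (a higher number here means a weaker inhibitor, a lower number a stronger inhibitor), compound 3 `O=C(c1cccc(/C=C2\CC(=O)N(c3ccccc3)C2=O)c1)N1CCCC1` sits at a limit of the assay, > 100000 nM, so no number for it is known. Compound 1 `Cc1ccc(NC(=O)c2cccc(/C=C3\CC(=O)N(c4ccccc4)C3=O)c2)cc1` likewise sits at a limit in this assay, > 100000 nM. Compound 2 `Cc1cccc(NC(=O)c2cccc(/C=C3\CC(=O)N(c4ccccc4)C3=O)c2)c1` also sits at a limit, > 100000 nM. The steps a step that the two limits leave unreadable from compound 1 to compound 2, a step that the two limits leave unreadable from compound 1 to compound 3 and a step that the two limits leave unreadable from compound 2 to compound 3 are all of unreadable size because of the limit of > 100000 nM in this assay, at which 3 of the 3 values shown sit. Compound 4 `CSc1cccc(NC(=O)c2cccc(/C=C3\CC(=O)N(c4ccccc4)C3=O)c2)c1` differs from compound 3 by (3-(methylsulfanyl)phenyl)amino in place of pyrrolidin-1-yl on a carbonyl carbon. Going by the values given here, none of the measured steps gives a readable size or direction for this change, so no step beyond the scatter can be foreseen, and compound 4 is expected to sit at the same limit as the others. Compound 4 is estimated at 100000 nM, within 50000 nM to 300000 nM. This corresponds to an expected step of a number no higher from compound 3 to compound 4 (the limit leaves the size open).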

Compound 4, half-maximal inhibitory concentration: 74300 nM
Beside the measured number, compound 4's estimate is 1.3-fold (0.13 log units) above it; measured number inside the range.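

Compound 4 alone among the compounds shown gives a number rather than a limit in this assay. Pyrrolidin-1-yl giving way to (3-(methylsulfanyl)phenyl)amino on a carbonyl carbon is an at least 1.3-fold lower number from compound 3 to compound 4 (0.12 log units; that floor lies within the scatter), methylsulfanyl in place of methyl on an aromatic carbon is an at least 1.3-fold lower number from compound 2 to compound 4 (0.12 log units; that floor lies within the scatter), and 3-(methylsulfanyl)phenyl in place of 4-methylphenyl on an amide-type nitrogen is an at least 1.3-fold lower number from compound 1 to compound 4 (0.12 log units; that floor lies within the scatter). These three are only floors, and the steps among the other compounds cannot be read, because of one limit: the limit of > 100000 nM in this assay, at which 3 of the 4 values shown sit.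

The compounds shown leave open how far each true step runs. They also leave open whether methoxy or chloro in place of methylsulfanyl on that aromatic carbon would likewise give a number.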